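The compounds below may be only part of what the source reports. "The series", "measured", "known", "first", "only" and "open" are said of these compounds alone.

Compounds measured so far in a functional assay on HL-60 cells (Homo sapiens) for inhibition, read by MTT assay, with a stated time of 72 h; on this read-out lower numbers stand for stronger inhibition and higher numbers for weaker inhibition:

compound 1 `Cc1nc(-c2ccccc2F)c(C(=O)N2CCN(c3cc(Cl)cc(Cl)c3)CC2)o1`: 60.2 nM
compound 2 `COc1ccc(Cl)cc1N1CCN(C(=O)c2oc(C)nc2-c2ccccc2F)CC1`: 153 nM
compound 3 `COc1cc(OC)cc(N2CCN(C(=O)c3oc(C)nc3-c3ccccc3F)CC2)c1`: 10.3 nM

Compound 3 gives the lowest number of the three. Its nearest neighbour is compound 1, as a 5.8-fold lower number from compound 1 to compound 3 (0.77 log units; beyond the scatter) shows; compound 2 lies further off, with a 15-fold lower number from compound 2 to compound 3 (1.17 log units; beyond the scatter). The remaining step, a 2.5-fold higher number from compound 1 to compound 2 (0.41 log units; beyond the scatter), fills in the picture: every change measured so far sits on the amine nitrogen in the ring, where the aryl group on that nitrogen was swapped.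

Compound 4 `COc1cc(OC)cc(N2CCN(C(=O)c3oc(C)nc3-c3cccc(F)c3)CC2)c1` keeps the 3,5-dimethoxyphenyl of compound 3 and differs only at the other end of the shared core: 3-fluorophenyl in place of 2-fluorophenyl on an aromatic carbon. Among the measured compounds shown here, no measured step touches this position; the three steps recorded all concern the aryl group on the amine nitrogen and say nothing about moving the fluorine on the phenyl attached to the five-membered ring. For the measured compounds named here, the only guide is that compound 3 stands at the strong end of the range and that a one-atom shift of this kind, in the absence of any data, most often lands within scatter or a modest step weaker.

Compound 4 is therefore expected near compound 3, with an estimated step of a 1.6-fold higher number from compound 3 to compound 4 (0.19 log units; within the scatter), giving an estimate of 16 nM with a range from 6 nM to 45 nM.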

Compound 4, half-maximal inhibitory concentration: 28.2 nM
Estimate against measurement, compound 4: 1.8-fold (0.25 log units) below, and the stated range covers the measured number.
By their numbers in this assay, from the lowest: compound 3; then compound 4; then compound 1; then compound 2.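

In this assay, among the compounds shown here, 3-fluorophenyl in place of 2-fluorophenyl on an aromatic carbon of the five-membered ring gives a 2.7-fold higher number from compound 3 to compound 4 (0.44 log units; beyond the scatter) and is the first measured step at this end of the shared core. Compound 3 and compound 4 have the same atoms, joined differently, and the 3,5-dimethoxyphenyl on the amine nitrogen is unchanged, so the location of the fluorine alone moves the number beyond the scatter, showing that the response in this series is not confined to the aryl group on the amine nitrogen. Nothing available on this pair offers an explanation for the step.

This single pair, with 3,5-dimethoxyphenyl on the amine nitrogen, leaves open whether 2-fluorophenyl would also give the lower number with 3,5-dichlorophenyl or 5-chloro-2-methoxyphenyl on that nitrogen. The compounds shown also leave open how 4-fluorophenyl, unsubstituted phenyl or 2-chlorophenyl would compare on the same aromatic carbon, and whether an ethyl group or an amine in place of the methyl group on the five-membered ring would shift the number in either direction.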